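The source may report more compounds than this note shows. Statements on the series, on what has been measured and on what is new or still open speak of the compounds shown alone.

Measured in an assay for inhibition of Amine oxidase [flavin-containing] A (Rattus norvegicus); a lower number here means a stronger inhibitor, a higher number a weaker inhibitor:
compound 1, `COc1cccc(COc2ccc(-c3nn(CCC#N)c(=S)o3)cc2)c1`, gives 8100 nM
compound 2, `N#CCCn1nc(-c2ccc(OCc3ccc([N+](=O)[O-])cc3)cc2)oc1=S`, gives 2600 nM
compound 3, `Cc1cccc(COc2ccc(C3=NN(CCC#N)C(=O)CO3)cc2)c1`, gives 40000 nM

Among these three, compound 3 carries the highest number, and therefore stands as the weakest inhibitor in this assay; the nearest to it is compound 1, from which it lies a clear distance away, and compound 2 lies further still. Compound 3 also differs from compounds 1 and 2 in its core, so only the outer group is shared ground.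

Compound 4, `N#CCCN1N=C(c2ccc(OCc3ccc(Cl)cc3)cc2)OCC1=O`, is compound 3 with 4-chlorophenyl in place of 3-methylphenyl on a saturated chain carbon bound to an oxygen on an aromatic ring. Among the compounds with values here, only one measured step bears on this change, and only loosely: a 3.1-fold lower number from compound 1 to compound 2 (0.49 log units; beyond the scatter), which swaps the same sort of group at the same place but on the other core and with different substituents. It points toward a lower number, though it gives no direct guide for a chlorine in place of a methyl. Compound 4 is therefore expected to come in somewhat below compound 3 in this assay, with an expected step of a 2.0-fold lower number from compound 3 to compound 4 (0.30 log units; within the scatter), a change not far beyond the scatter. For compound 4 the estimate in this assay is 20000 nM, within a range from 7000 nM to 55000 nM.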

Compound 4, half-maximal inhibitory concentration: 3400 nM
Estimate against measurement, compound 4: 5.9-fold (0.77 log units) above; the measured number lies below the stated range.
By their numbers in this assay, from the lowest: compounds 2 and 4 (each within the scatter of the next); then compound 1; then compound 3.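

In this assay, the group on a saturated chain carbon bound to an oxygen on an aromatic ring proves to matter greatly on the core shared by compound 3 and compound 4 (a 12-fold lower number from compound 3 to compound 4 (1.07 log units; beyond the scatter)). Within the data shown here, the only earlier step at this place was a modest one, taken on a different core and with different groups (a 3.1-fold lower number from compound 1 to compound 2 (0.49 log units; beyond the scatter)), so it did not show that a change here could have so large an effect. The two groups exchanged here have the same heavy-atom count and the same kind of ring, so those counts do not separate them, and nothing at hand accounts for the size of the step.

The change alters both the substituent and its place on the ring, so the compounds shown cannot say whether the chlorine or its location carries the step; a 3-chlorophenyl or a 4-methylphenyl group would separate the two. Also open, from the compounds shown here alone, are whether the same exchange would have a similar effect on the core of compound 1, and how an amine or a carboxylic acid on this ring would read.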